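A few compounds are considered here, and "the series" means these few. Any claim that something is new, unique, unknown or untested is made for them only; others in the source may bear on it.

Values so far in a functional assay on brain (Rattus norvegicus, strain Wistar) for inhibition; a higher number here means a weaker inhibitor, a lower number a stronger inhibitor
- compound 1 `CCCCOc1ccc(-c2c(C)[nH]c(=O)n2C2CCCCC2)cc1` gives 13900 nM 
- compound 2 `CCCCCc1ccc(-c2c(C)[nH]c(=O)n2C)cc1` gives 5900 nM 
- compound 3 `CCCc1ccc(-c2c(C)[nH]c(=O)n2C2CCCCC2)cc1` gives 13900 nM 

Compound 3 stands level with compound 1, and these two share the highest number of the three, with compound 2 lower. Compound 4 `CCCCCc1ccc(-c2c(C)[nH]c(=O)n2C2CCCCC2)cc1` comes from compound 3 by one change, (ethyl in place of hydrogen on a saturated chain carbon, three bonds along the chain from an aromatic carbon), with ethyl in place of hydrogen on a saturated chain carbon, three bonds along the chain from an aromatic carbon, so that propyl becomes pentyl.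

Among the compounds with values here, only one measured step bears on this. It is no change at the digits printed from compound 1 to compound 3 (within the scatter), with propyl in place of butoxy, and it stays within the scatter. Within the data shown here, no measured step isolates this lengthening. Compound 2 also carries pentyl and gives 5900 nM in this assay, but it differs from compound 4 in another place too, so it suggests only a slight lean towards a lower number. The expected change, a 1.4-fold lower number from compound 3 to compound 4 (0.14 log units; within the scatter), is therefore small and probably within the scatter. For compound 4 the estimated value is 10000 nM, with an expected range from 4000 nM to 25000 nM, and the measurement is still to come.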

Compound 4, half-maximal inhibitory concentration: 10600 nM
For compound 4 the middle estimate is 1.1-fold (0.03 log units) below the measured one, within the range that was stated.
By their numbers in this assay, from the lowest: compounds 2, 4, 1 and 3 (each within the scatter of the next, the first and the last beyond it).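

In this assay, the step that adds ethyl to the saturated chain carbon, turning propyl into pentyl, is a 1.3-fold lower number from compound 3 to compound 4 (0.12 log units; within the scatter), so this position shows no change beyond the scatter for this lengthening. The other two single changes, a 1.3-fold lower number from compound 1 to compound 4 (0.12 log units; within the scatter) with pentyl in place of butoxy and a 1.8-fold higher number from compound 2 to compound 4 (0.25 log units; within the scatter) with cyclohexyl in place of methyl on the aromatic nitrogen, also stay within the scatter, which means that none of the three steps separates compound 4 from its neighbours. Nothing at hand offers an explanation for this result.

As far as these compounds go, whether a longer chain such as heptyl, or an amine or a carboxylic acid at the end of the pentyl chain, would move the number beyond the scatter remains open. Also open, from the compounds shown here alone, is how a phenyl group in place of cyclohexyl on the aromatic nitrogen would read in this assay.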